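The source may report more compounds than this note shows. Statements on the series, on what has been measured and on what is new or still open speak of the compounds shown alone.

Compound 1 `COC(=O)c1ccc(NCc2cncn2Cc2ccccc2C(C)(C)C)cc1-c1ccccc1`: "not determined" (no result reported)
Compound 2 `COC(=O)c1ccc(NCc2cncn2Cc2ccc(N)cc2)cc1-c1ccccc1`: > 10000 nM
Compound 3 `COC(=O)c1ccc(NCc2cncn2Cc2ccc(C#N)cc2)cc1-c1ccccc1`: > 10000 nM

The three measured compounds share one core and differ only in the group on the benzyl ring; all were tested in a toxicity assay on NIH3T3 cells (Mus musculus) for cytotoxicity, read by resazurin assay; on this read-out lower numbers stand for an effect already at smaller amounts and higher numbers for an effect only at larger amounts of compound. For compound 1 the outcome is "not determined" (no result reported). Compound 2 reaches only a limit of this assay, > 10000 nM. Compound 3 likewise shows only a limit of this assay, > 10000 nM. So compound 3 stands at the limit, with no number of its own. Within the data shown here, the single step between measured compounds, a step that the two limits leave unreadable from compound 2 to compound 3, cannot be sized because the limit of > 10000 nM in this assay, at which 2 of the 3 values shown sit, is where both of its values sit. Compound 4 `COC(=O)c1ccc(NCc2cncn2Cc2ccc(C)cc2)cc1-c1ccccc1` differs from compound 3 by methyl in place of cyano on an aromatic carbon. Among the measured compounds shown here, no measured step gives this change a size, and no measured value places any compound away from the limit, so a step that the limit leaves unreadable from compound 3 to compound 4 of no readable size is expected. Compound 4 is therefore estimated at 20000 nM in this assay, in a range from 8000 nM to 60000 nM, most likely again reported only as a limit.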

Compound 4, half-maximal effective concentration: 50000 nM
Estimate against measurement, compound 4: 2.5-fold (0.40 log units) below; measured number inside the range.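

No step to compound 4 can be read from compound 2 or compound 3 in this assay, because the values of those two compounds are limits and not numbers: the limit of > 10000 nM in this assay, at which 2 of the 4 values shown sit.

The compounds shown leave open whether the amino, cyano and methyl groups differ at all in their effect in this assay.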